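Dropping one bromine from an inactive flavone analogue

The source may report more compounds than this note shows. Statements on the series, on what has been measured and on what is new or still open speak of the compounds shown alone.

Compound 1, with the structure `O=c1cc(-c2ccccc2)oc2ccc(N3COc4c(Br)cc(Br)cc4C3)cc12`, was tested in a functional assay on MCF7 cells (Homo sapiens) for inhibition, read by MTT assay, with a stated time of 48 h (a lower number here means a stronger inhibitor, a higher number a weaker inhibitor), where compound 1 came out as "not active" (no number reported), so no number places it on the scale. Two close relatives give some orientation. Compound 2, with the structure `O=c1cc(-c2ccccc2)oc2cc(N3COc4c(Cl)cc(Cl)cc4C3)ccc12`, gives 44500 nM in this assay, and compound 3, with the structure `O=c1cc(-c2ccccc2)oc2ccc(N3COc4c(Cl)cc(Cl)cc4C3)cc12`, gives 12000 nM in this assay. Both carry chlorine rather than bromine, and both are weak inhibitors, with compound 3 the better of the two.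

Compound 4, with the structure `O=c1cc(-c2ccccc2)oc2ccc(N3COc4c(Br)cccc4C3)cc12`, is the next one to be tested. Compared with compound 1, the change is hydrogen in place of bromo on an aromatic carbon. Among the measured compounds shown here, no measured pair in this set shows what such a removal does, and the starting point itself has no number, so the size and direction of the step in this assay cannot be read from the data; any effect may well stay within the scatter.

Given that compound 3, the closest measured analogue, gives 12000 nM, and that compound 1 gave no measurable inhibition, compound 4 is expected to be a weak inhibitor at best, with an estimated value of 30000 nM in a range from 8000 nM to 150000 nM, and a real chance that it too comes out as not active.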

Compound 4, half-maximal inhibitory concentration: 19600 nM
The estimate for compound 4 lay 1.5-fold (0.18 log units) above the measured number; the measured number falls inside the stated range.
By their numbers in this assay, from the lowest: compounds 3 and 4 (each within the scatter of the next); then compound 2.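

Compound 1 has no number in this assay, so the loss of one bromo group on going to compound 4, which gives 19600 nM, cannot be read as a step. The compounds shown leave open whether removing that bromo group changes inhibition at all, and in which direction. No measurement shown here explains the result.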